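From a Butyl Chain to a Bromophenylsulfonyl Group

The compounds below may be only part of what the source reports. "The series", "measured", "known", "first", "only" and "open" are said of these compounds alone.

Of the compounds shown here, three sharing one core have been tested in a functional assay on HEK293 cells (Homo sapiens) for cytotoxicity; a lower number here means that less compound is tolerated, a higher number that more compound is tolerated. Compound 1 `COc1ccc([C@H]2CC(=O)N(c3cc(N)cc(N)c3)C2)cc1OC1CCCC1` gives > 10000 nM, which is a limit of the assay rather than a number. Compound 2 `COc1ccc([C@H]2CC(=O)N(c3ccc(S(C)(=O)=O)cc3)C2)cc1OC1CCCC1` likewise gives > 10000 nM, again a limit. Compound 3 `CCCCNc1cccc(N2C[C@@H](c3ccc(OC)c(OC4CCCC4)c3)CC2=O)c1` gives > 10000 nM, also a limit. Going by the values given here, the step that the two limits leave unreadable from compound 1 to compound 2 therefore cannot be read, and every value so far sits at the limit of > 10000 nM in this assay, at which 3 of the 3 values shown sit. Compound 4 `COc1ccc([C@H]2CC(=O)N(c3cccc(NS(=O)(=O)c4cccc(Br)c4)c3)C2)cc1OC1CCCC1` differs from compound 3 in that ((3-bromophenyl)sulfonyl in place of butyl on a nitrogen on an aromatic ring). Among the compounds with values here, no measured step bears on this exchange, so the shared behaviour of compounds 1, 2 and 3 is the only guide. Compound 4 is expected to land near the same limit, an estimated 10000 nM with a range from 5000 nM to 30000 nM. This amounts to an expected step of a number no higher from compound 3 to compound 4 (the limit leaves the size open) of no readable size.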

Compound 4, half-maximal cytotoxic concentration: > 10000 nM
Compound 4 was reported as a limit; the forecaster's own chance of this, stated with the estimate: 85%; the middle value lies on the limit itself.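

Going by these compounds alone, compound 3 and compound 4 are both reported only as limits, so the exchange of butyl for (3-bromophenyl)sulfonyl gives no step that can be read. The compounds shown leave open at what concentration, if any, each would reach the half-maximal cytotoxic read-out in this assay.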